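The source may report more compounds than this note shows. Statements on the series, on what has been measured and on what is new or still open speak of the compounds shown alone.

Of the compounds shown here, three built on one shared core have been measured in a functional assay, tested at 50 ug/mL; a higher number here means a stronger effect of the compound at the concentration tested, a lower number a weaker effect. Compound 1 `COc1ccc(C2C(C#N)=C(N)OC(c3c[nH]c4ccccc34)=C2C#N)cc1OC` gives 14.5%, compound 2 `CN(C)c1ccc(C2C(C#N)=C(N)OC(c3c[nH]c4ccccc34)=C2C#N)cc1` gives 14.4%, and compound 3 `Cc1ccc(C2C(C#N)=C(N)OC(c3c[nH]c4ccccc34)=C2C#N)cc1` gives 5.2%. Compound 2 stands second highest of these three numbers; compound 1 is nearest to it (a number 0.1 percentage points lower from compound 1 to compound 2 (within the scatter)) and compound 3 furthest (a number 9.2 percentage points lower from compound 2 to compound 3 (within the scatter)). Compound 4 `N#CC1=C(N)OC(c2c[nH]c3ccccc23)=C(C#N)C1c1ccccc1` differs from compound 2 in one place: hydrogen in place of dimethylamino on an aromatic carbon. The measured step that bears most on this change is a number 9.2 percentage points lower from compound 2 to compound 3 (within the scatter), which removed the same dimethylamino group in favour of methyl; the related step of a number 9.3 percentage points lower from compound 1 to compound 3 (within the scatter) was of similar size. Neither left the scatter, so in this assay no step beyond the scatter is expected, at most a small drop, a number 5.4 percentage points lower from compound 2 to compound 4 (within the scatter). Compound 4 is therefore estimated at 9%, ranging from 0% to 20%.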

Compound 4, a percentage reported as activity, at one concentration (the size of the read-out at that concentration, not a potency): 14.4%
Compound 4: the middle estimate sits 5.4 percentage points below what was measured, within the range that was stated.
By their numbers in this assay, from the lowest: compounds 3, 2, 4 and 1 (each within the scatter of the next).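

Taking dimethylamino off altogether costs nothing measurable in this assay (no change at the digits printed from compound 2 to compound 4 (within the scatter)), and the bare phenyl also stays within the scatter of 3,4-dimethoxyphenyl (a number 0.1 percentage points lower from compound 1 to compound 4 (within the scatter)), so neither substituent is needed to reach this level. Hydrogen in place of methyl on the same aromatic carbon likewise stays within the scatter (a number 9.2 percentage points higher from compound 3 to compound 4 (within the scatter)), so every step at this position so far lies within it. No measurement given here accounts for these numbers. Going by these compounds, whether a carboxylic acid, a primary amine or a longer alkyl chain on this carbon would move the read-out beyond the scatter remains open.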